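A few compounds are considered here, and "the series" means these few. Any claim that something is new, unique, unknown or untested is made for them only; others in the source may bear on it.

Compound 1 `CCC1=C(N2CC2)C(=O)C(CCOC(N)=O)=C(N2CC2)C1=O` gives 5.48 in a functional assay on L1210 cells (Mus musculus), with a stated time of 12 days (on this read-out lower numbers stand for lower potency and higher numbers for higher potency (the scale is a negative logarithm)), the higher of the two numbers recorded there. Its neighbour compound 2 `CCCC1=C(N2CC2)C(=O)C(CCOC(N)=O)=C(N2CC2)C1=O` gives 5.23, and the step of a number 0.25 log units lower from compound 1 to compound 2 (within the scatter) is within the scatter, so the two cannot be told apart. Compound 3 `CCOC(COC(N)=O)C1=C(N2CC2)C(=O)C(CC)=C(N2CC2)C1=O` has not yet been tested. It differs from compound 1 in one place: ethoxy in place of hydrogen on a saturated chain carbon bound to a double-bonded ring carbon and a saturated chain carbon. Within the data shown here, no measured step adds an ethoxy group at this place, so the only guide is the single step from compound 1 to compound 2, where a small addition to the same chain left the number essentially unchanged. On that basis no change beyond the scatter is expected, with a wide range because the added group is larger than anything tried so far. Compound 3 is therefore estimated at 5.3, between 4.6 and 6, a step of a number 0.18 log units lower from compound 1 to compound 3 (within the scatter) that is expected to stay within the scatter.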

Compound 3, logarithm of the reciprocal of the active concentration, log(1/C): 5.24
For compound 3 the middle estimate is 0.06 log units above the measured one; the range from low to high includes it.
By their numbers in this assay, from the lowest: compounds 2, 3 and 1 (each within the scatter of the next).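

Placing ethoxy on a saturated chain carbon bound to a double-bonded ring carbon and a saturated chain carbon gives a number 0.24 log units lower from compound 1 to compound 3 (within the scatter) in this assay, so the two compounds cannot be told apart. This place therefore accepts a group of 3 heavy atoms, with 1 hydrogen-bond acceptor, without a step beyond the scatter, and the earlier step from compound 1 to compound 2 could not show that because it concerned a different carbon. Nothing available explains why the number holds here.

A single ethoxy group says little about the range of groups this carbon can carry. An amine, a carboxylic acid or a longer chain such as butoxy at this carbon could still give a step beyond the scatter, and the compounds shown do not settle that.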